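Fluoro for chloro on the aryl of compound 1

The source may report more compounds than this note shows. Statements on the series, on what has been measured and on what is new or still open speak of the compounds shown alone.

Measured so far:
compound 1 `CCCc1nc(-c2ccccc2)c(CNCCCN2CCN(c3ccccc3Cl)CC2)o1` — 64.7%
compound 2 `CCCc1nc(-c2ccccc2)c(CNCCN2CCN(c3cccc(C)c3C)CC2)o1` — 66.7%

In an assay on HEK293 cells for inhibition of Voltage-dependent T-type calcium channel subunit alpha-1G (Homo sapiens), read by fluorescence, tested at 10 uM (a higher number here means more inhibition at the concentration tested (going by the name of the read-out), a lower number less inhibition), compound 1 gives 64.7%, the lower of the two numbers; compound 2 gives 66.7%, and the two lie within the scatter of each other, so nothing separates them. Compound 3 `CCCc1nc(-c2ccccc2)c(CNCCCN2CCN(c3ccccc3F)CC2)o1` is not yet measured. It differs from compound 1 by one change: fluoro in place of chloro on an aromatic carbon. Among the measured compounds shown here, no measured pair shows this change, so its effect rests on no number. For compound 3 in this assay a small loss at most is expected, not clearly beyond the scatter. Compound 3 is estimated at 57%, within 40% to 74%. The step of a number 7.7 percentage points lower from compound 1 to compound 3 (within the scatter) is thus expected to be modest.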

Compound 3, a percentage reported as inhibition, at one concentration (the size of the read-out at that concentration, not a potency): 54.4%
Beside the measured number, compound 3's estimate is 2.6 percentage points above it; measured number inside the range.
By their numbers in this assay, from the lowest: compound 3; then compounds 1 and 2 (each within the scatter of the next).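

Going from 2-chlorophenyl to 2-fluorophenyl in this assay gives a number 10.3 percentage points lower from compound 1 to compound 3 (beyond the scatter), the first step in the series that changes one place only. The aromatic carbon ortho to a large group therefore responds to which halogen it carries, though neither halogen abolishes inhibition at the concentration tested. Nothing available explains this step.

From the compounds shown here alone, whether a methoxy or trifluoromethyl group in place of the halogen, or plain phenyl, would give more or less inhibition stays open. So does whether this step carries over to a different chain.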